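The compounds below may be only part of what the source reports. "The series", "measured", "known", "first", "only" and "open" are said of these compounds alone.

Compound 1 `Cc1ccc(C(=O)Nc2ccc(Cl)cc2C(N)=O)cc1` gives 5.39 ug/mL in a functional assay on MCF7 cells (Homo sapiens) for antiproliferative activity, read by MTT assay, with a stated time of 48 h; a higher number here means a weaker inhibitor, a lower number a stronger inhibitor.
Compound 2 `Cc1ccc(-c2nc3ccc(Cl)cc3c(=O)[nH]2)cc1` gives 4.98 ug/mL in this assay.

Of these two numbers compound 2 has the lower one, yet the gap to compound 1 is small enough to sit within the ordinary scatter of repeated measurements, so the two compounds cannot be told apart on this evidence. Compound 3 `Cc1ccc(-c2nc3ccc(Cl)cc3c(=O)n2N)cc1` has not yet been measured. It differs from compound 2 by amino in place of hydrogen on an aromatic nitrogen. Among the measured compounds shown here, no measured pair here shows what a change of this kind does, so there is no step to lean on. With only the amino group added, a modest shift is expected in this assay, with no firm direction and most likely nothing beyond the scatter. Compound 3 is therefore estimated at 4.5 ug/mL, within a range from 2 ug/mL to 10 ug/mL. This estimate means a step of a 1.1-fold lower number from compound 2 to compound 3 (0.04 log units; within the scatter), expected to stay within the scatter.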

Compound 3, half-maximal inhibitory concentration: 5.39 ug/mL
Compound 3: the middle estimate sits 1.2-fold (0.08 log units) below what was measured; low and high end bracket the measured number.
By their numbers in this assay, from the lowest: compounds 2, 1 and 3 (each within the scatter of the next).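

Among the compounds shown here, this is the first pair in which only the group on the aromatic nitrogen differs, and amino in place of hydrogen gives a 1.1-fold higher number from compound 2 to compound 3 (0.03 log units; within the scatter). In this assay, the added amino group therefore cannot be told apart from the hydrogen it replaces, so this single change leaves antiproliferative activity on these cells without a detectable shift. No measurement given here offers an explanation for this result.

This one pair does not show whether other groups would be tolerated equally well at this nitrogen, so a methyl group, a longer chain such as propyl, or a carboxylic acid could still move the number beyond the scatter. It also leaves open whether the amino group would behave the same way if the chlorine on the shared core were replaced by fluorine or methoxy.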